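Tetrabrominated core with hydroxyalkyl chains: antiproliferative screen

The compounds below may be only part of what the source reports. "The series", "measured", "known", "first", "only" and "open" are said of these compounds alone.

Measured compounds:
compound 1 `OCC(O)Cn1nc2c(Br)c(Br)c(Br)c(Br)c2n1`: 60%
compound 2 `OC(CCn1nc2c(Br)c(Br)c(Br)c(Br)c2n1)c1ccccc1`: 89%
compound 3 `CC(O)CCn1nc2c(Br)c(Br)c(Br)c(Br)c2n1`: 94%

Three compounds share the core of compound 1 and differ only in the chain on the aromatic nitrogen. In a functional assay on CCRF-CEM cells (Homo sapiens) for antiproliferative activity, read by MTT assay, with a stated time of 48 h, tested at 12.5 uM (a lower number here means a stronger effect, a higher number a weaker effect of the compound at the concentration tested), compound 1 gives 60%, compound 2 gives 89% and compound 3 gives 94%. Compound 3 holds the highest of the three numbers; compound 2 lies nearest, the two within the scatter, while compound 1 is farthest, with a number 34 percentage points higher from compound 1 to compound 3 (beyond the scatter).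

Within the data shown here, compound 4 `COc1cccc(C(O)CCn2nc3c(Br)c(Br)c(Br)c(Br)c3n2)c1` is not yet measured. 3-methoxyphenyl in place of methyl on a saturated chain carbon bound to an oxygen on a saturated carbon and a saturated chain carbon The one measured step at this place is a number 5 percentage points higher from compound 2 to compound 3 (within the scatter), which stays within the scatter. Among the measured compounds shown here, compound 4 carries a ring related to that of compound 2, with an added methoxy, and no measured step covers the methoxy itself. The step of a number 7 percentage points lower from compound 3 to compound 4 (within the scatter) is therefore expected to be small, leaning toward the number of compound 2 because compound 2 gives 89%. For compound 4 the value in this assay is estimated at 87%, with a range from 68% to 100%.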

Compound 4, a percentage reported as activity, at one concentration (the size of the read-out at that concentration, not a potency): 96%
Beside the measured number, compound 4's estimate is 9 percentage points below it; measured number inside the range.
By their numbers in this assay, from the lowest: compound 1; then compounds 2, 3 and 4 (each within the scatter of the next).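

At this chain carbon, 3-methoxyphenyl in place of methyl gives a number 2 percentage points higher from compound 3 to compound 4 (within the scatter) in this assay, so a far larger group with an aromatic ring reads no differently from methyl within the scatter. A first substituent on that ring, methoxy in place of hydrogen on an aromatic carbon, gives a number 7 percentage points higher from compound 2 to compound 4 (within the scatter) and likewise leaves the reading within the scatter, so neither change at this position separates these compounds. No measurement is available that would account for this.

Still open, from the compounds shown here alone, is whether an amine or a carboxylic acid on this chain carbon would bring the number nearer to compound 1 at 60% in this series. Whether a longer chain would do so is equally unsettled.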